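From chloro to hydroxy in compound 4

The source may hold more compounds than are shown below. What is called first, only, known or untested is meant among the compounds shown, and "the series" means these compounds.

Compound 1 `O=C(/C(=C\c1ccc(Cl)c([N+](=O)[O-])c1)S(=O)(=O)c1ccc(Br)cc1)c1ccc(Br)cc1` gives 10000 nM
Compound 2 `O=C(/C(=C\c1ccc(Cl)c([N+](=O)[O-])c1)Sc1ccc(Br)cc1)c1ccc(Br)cc1` gives 10000 nM
Compound 3 `O=C(/C(=C\c1ccc(Cl)cc1)Sc1ccc(Br)cc1)c1ccc(Br)cc1` gives 1000 nM

In a functional assay on DU-145 cells (Homo sapiens) for inhibition, read by trypan blue exclusion, with a stated time of 96 h (on this read-out higher numbers stand for weaker inhibition of growth and lower numbers for stronger inhibition of growth), compound 1 and compound 2 share the same number, and compound 3 lies lower. Among the compounds with values here, compound 4 `O=C(/C(=C\c1ccc(O)c([N+](=O)[O-])c1)Sc1ccc(Br)cc1)c1ccc(Br)cc1` has hydroxy in place of chloro on an aromatic carbon and no measured step makes that exchange. The closest evidence is the step with hydrogen in place of nitro (a 10-fold lower number from compound 2 to compound 3 (1.00 log units; beyond the scatter)), yet compound 4 keeps its nitro group. The step with (4-bromophenyl)sulfanyl in place of (4-bromophenyl)sulfonyl (no change at the digits printed from compound 1 to compound 2 (within the scatter)) concerns another part of the molecule. In this assay the expected change (a 1.4-fold lower number from compound 2 to compound 4 (0.15 log units; within the scatter)) stays within the scatter. Compound 4 is estimated at 7000 nM with an expected range (2000 nM to 20000 nM).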

Compound 4, concentration for 50% growth inhibition: 1000 nM
Compound 4: middle estimate off by 7.0-fold (0.85 log units), on the high side; the whole stated range lies above it.
By their numbers in this assay, from the lowest: compounds 3 and 4 (each within the scatter of the next); then compounds 1 and 2 (each within the scatter of the next).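

In this assay, the ring position ortho to a nitro group and para to a large group responds to its substituent: hydroxy in place of chloro gives a 10-fold lower number from compound 2 to compound 4 (1.00 log units; beyond the scatter), a step beyond the scatter. The earlier compounds shown here showed a change of this kind only on removing the nitro group, whereas here the number falls with the nitro group still in place. Nothing measured accounts for this step.

On these data alone, whether a methoxy group or an amine at this position would act as hydroxy does remains open. The compounds shown also cannot tell whether the same exchange would hold in compound 1 or compound 3.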